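The compounds below may be only part of what the source reports. "The series", "measured", "known", "first", "only" and "open" are said of these compounds alone.

In a functional assay on Caco-2 cells (Homo sapiens) for antiproliferative activity, read by MTT assay, with a stated time of 48 h (a lower number here means a stronger inhibitor, a higher number a weaker inhibitor), compound 3 `C#CC(C)OC(=O)c1ccc(C(CC)(CC)c2ccc(OCCC(O)(CC)CC)c(C)c2)n1CC` gives > 50000 nM as a limit and not as a number. Compound 2 `CCn1c(C(=O)N(CCC#N)CCC#N)ccc1C(CC)(CC)c1ccc(OCCC(O)(CC)CC)c(C)c1` likewise gives > 50000 nM as a limit. For the measured compounds named here, only compound 1 `CCN(CC)CCNC(=O)c1ccc(C(CC)(CC)c2ccc(OCCC(O)(CC)CC)c(C)c2)n1CC` has a number, with 1630 nM as its reading in this assay so far.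

The change to compound 4 `CCC(C)C(NC(=O)c1ccc(C(CC)(CC)c2ccc(OCCC(O)(CC)CC)c(C)c2)n1CC)C(=O)O` puts (1-carboxy-2-methylbutyl)amino in place of (1-methylprop-2-yn-1-yl)oxy on a carbonyl carbon.

Going by the values given here, two measured steps bear on this change. The first is (an at least 30-fold higher number from compound 1 to compound 3 (1.48 log units; beyond the scatter)) and the second is (an at least 30-fold higher number from compound 1 to compound 2 (1.48 log units; beyond the scatter)). Both are large, but both end at a limit, so neither gives a true size. The third step (a step that the two limits leave unreadable from compound 2 to compound 3) adds nothing.

Compound 4 regains an amino link on the carbonyl carbon, as in compound 1 with 1630 nM as its reading, so some move towards a lower number is expected. Compound 2 goes against that reading, since it also has a nitrogen on that carbonyl carbon and still sits at a limit. Only a partial recovery is therefore expected.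

The step expected is an at least 3.3-fold lower number from compound 3 to compound 4 (0.52 log units; beyond the scatter) and the reading may well stay at the limit. Compound 4 is estimated at 15000 nM within a range of 2000 nM to 50000 nM in this assay as an expectation only.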

Compound 4, half-maximal inhibitory concentration: 20000 nM
Compound 4: the middle estimate sits 1.3-fold (0.12 log units) below what was measured; low and high end bracket the measured number.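

The change to (1-carboxy-2-methylbutyl)amino gives the first readable movement away from the limit at this carbonyl carbon, with an at least 2.5-fold lower number from compound 3 to compound 4 (0.39 log units; beyond the scatter), and the comparison with the group of compound 2 gives an at least 2.5-fold lower number from compound 2 to compound 4 (0.39 log units; beyond the scatter). Both steps are bounds only and the step between compound 2 and compound 3 cannot be read, as those two compounds carry a limit and not a number: the limit of > 50000 nM in this assay, at which 2 of the 4 values shown sit. In this assay, an amide link on this carbonyl carbon does not by itself restore the reading of compound 1, since 1-carboxy-2-methylbutyl in place of 2-(diethylamino)ethyl on the amide-type nitrogen gives a 12-fold higher number from compound 1 to compound 4 (1.09 log units; beyond the scatter), so the group on that nitrogen also counts.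

The compounds shown do not separate the roles of the carboxylic acid, the branched chain of compound 4 and the diethylamino group of compound 1 in that gap. A methyl ester in place of the carboxylic acid, or a 3-(diethylamino)propyl chain on the amide-type nitrogen, would bear on this question.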